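The compounds below may be only part of what the source reports. "The series", "measured", "known", "first", "only" and "open" are said of these compounds alone.

Compound 1, `COc1cccc(NC(=S)NC2CC(C)(C)Oc3ccc(Br)cc32)c1`, was tested in a functional assay on U-373MG ATCC cells (Homo sapiens) for inhibition, read by MTT assay, with a stated time of 72 h (on this read-out lower numbers stand for stronger inhibition and higher numbers for weaker inhibition), and gives 66000 nM, the highest of the three numbers recorded there. The two compounds measured beside it both give lower numbers: compound 2, `CC1(C)CC(NC(=O)NCc2ccccc2)c2cc(Br)ccc2O1`, gives 27000 nM, and compound 3, `CC1(C)CC(NC(=S)Nc2cccc(C#N)c2)c2cc(Cl)ccc2O1`, gives 7000 nM, the lowest number of the three. Both gaps from compound 1 lie beyond the usual scatter of repeated measurements.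

The account now turns to compound 4, `CC1(C)CC(NC(=S)NCc2ccccc2)c2cc(Br)ccc2O1`, which has not yet been measured in this assay. Its structure differs from that of compound 1 in one place:

benzyl in place of 3-methoxyphenyl on an amide-type nitrogen

Compound 4 thereby carries the benzyl group seen in compound 2 while keeping the thiocarbonyl and the bromine of compound 1. Within the data shown here, no measured pair in this set reproduces this exact change, so the size of the step cannot be read from a recorded step. Given that compound 2 gives 27000 nM and that compound 1 gives 66000 nM, a modest step toward a lower number is expected for compound 4, of a size that may only just exceed the scatter: a 2.2-fold lower number from compound 1 to compound 4 (0.34 log units; beyond the scatter). Compound 4 is estimated at 30000 nM, with a plausible range from 8000 nM to 100000 nM.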

Compound 4, half-maximal inhibitory concentration: 29000 nM
For compound 4 the middle estimate is 1.0-fold (0.01 log units) above the measured one, and the stated range covers the measured number.
By their numbers in this assay, from the lowest: compound 3; then compounds 2 and 4 (each within the scatter of the next); then compound 1.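

Among these compounds, on an amide-type nitrogen whose other neighbour is the thiocarbonyl carbon, benzyl in place of 3-methoxyphenyl gives a 2.3-fold lower number from compound 1 to compound 4 (0.36 log units; beyond the scatter) in this assay, which is the only step recorded at this position and shows that the group on this nitrogen can shift the number by a modest amount beyond the scatter. Compound 4, at 29000 nM, and compound 2, at 27000 nM, lie within the scatter of each other, so with benzyl on this nitrogen the thiocarbonyl and carbonyl compounds are not told apart in this read-out. No measurement shown here explains the step from the 3-methoxyphenyl to the benzyl compound.

The change swaps the methoxy-bearing ring for a ring joined through a methylene, so the compounds shown do not separate these two differences; a plain phenyl or a 2-phenylethyl group on the same nitrogen would be needed to do so. Compound 3 differs from compound 1 in more than one place, which leaves open how much of its lower number belongs to the nitrile and how much to the chlorine.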